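The compounds below may be only part of what the source reports. "The series", "measured", "known", "first", "only" and "open" are said of these compounds alone.

Measured in a functional assay on HCT-116 cells (Homo sapiens) for inhibition; a higher number here means a weaker inhibitor, a lower number a stronger inhibitor:
- Compound 1 `C(=C\c1ccc2[nH]ccc2c1)\c1ccc2ccccc2c1`: > 5000 nM
- Compound 2 `Cn1ccc2cc(/C=C/c3ccc4ccccc4c3)ccc21`: > 5000 nM

Both entries are limits, not numbers. Compound 2 stands at the limit of > 5000 nM in this assay, at which 2 of the 2 values shown sit. Compound 3 `Cn1ccc2cc(/C=C\c3ccc4ccccc4c3)ccc21` has the same atoms and bonds as compound 2, and the two differ only in configuration as drawn: the two compounds have the same atoms and bonds and differ only in configuration as drawn: 1 of 1 stereo elements differ; a double bond is drawn E in compound 2 and Z in compound 3. Within the data shown here, no measured pair shows what such a change does, so its size remains a judgement. A moderate gain in strength in this assay is expected, though compound 3 could also end at a limit. The expected change is an at least 3.3-fold lower number from compound 2 to compound 3 (0.52 log units; beyond the scatter). Compound 3 is estimated at 1500 nM, with an expected range of 150 nM to 8000 nM.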

Compound 3, half-maximal inhibitory concentration: > 5000 nM
Compound 3 gave a limit, no number; the forecaster's own chance of this, stated with the estimate: 40%; at least 3.3-fold (0.52 log units) between middle value and limit.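

Compound 1, compound 2 and compound 3 all end at a limit in this assay, so the steps among them cannot be read. As far as these compounds go, whether double-bond configuration or the methyl on the aromatic nitrogen affects strength remains open.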